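Swapping a phenyl for an isoquinoline: expected clearance

This account rests on a few compounds, and the source may have more. Where it says the series, first, only, none or still open, it means among the compounds named here.

Of the compounds shown here, three share one core and have been measured in an ADME assay on the whole organism (Mus musculus, strain CD1) for pharmacokinetics, read by LC-MS, using cassette dosing, with a stated time of 24 h, at a dose of 0.4 mg/kg by the intravenous route; a higher number here means faster removal of the compound, a lower number slower removal. Compound 1 `Cc1cn(-c2cc(NC(=O)c3ccc(C)c(Nc4nccc(-c5ccccc5)n4)c3)cc(N3CCNCC3)c2)cn1` gives 52.5 mL/min/kg. Compound 2 `Cc1cn(-c2cc(NC(=O)c3ccc(C)c(Oc4ccccc4)c3)cc(C(F)(F)F)c2)cn1` gives 12.5 mL/min/kg. Compound 3 `Cc1cn(-c2cc(NC(=O)c3ccc(C)c(Oc4ccccc4)c3)cc(N3CCN(C)CC3)c2)cn1` gives 17.5 mL/min/kg, which places it second highest of the three, close to compound 2 and well apart from compound 1. The one single-point step among these, a 1.4-fold higher number from compound 2 to compound 3 (0.15 log units; within the scatter), is a change within the scatter; compound 1 differs from the others in more than one place, so its gap tells nothing about any single change.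

The next compound, compound 4 `Cc1cn(-c2cc(NC(=O)c3ccc(C)c(Oc4cccc5ccncc45)c3)cc(N3CCN(C)CC3)c2)cn1`, differs from compound 3 in one place: isoquinolin-8-yl in place of phenyl on an oxygen on an aromatic ring. Going by the values given here, no measured step involves this change, and no measured compound carries an isoquinolinyl group on that oxygen, so there is nothing in these numbers that points to a direction. Among the compounds with values here, the only guide is that the one measured single change stayed within the scatter.

The expectation for compound 4 is therefore a step of about a 1.0-fold higher number from compound 3 to compound 4 (0.01 log units; within the scatter), that is, no change beyond the scatter. Compound 4 is estimated at 18 mL/min/kg, with a likely range from 9 mL/min/kg to 36 mL/min/kg.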

Compound 4, clearance: 50.8 mL/min/kg
Compound 4: middle estimate off by 2.8-fold (0.45 log units), on the low side; measured number outside the range, above it.
By their numbers in this assay, from the lowest: compounds 2 and 3 (each within the scatter of the next); then compounds 4 and 1 (each within the scatter of the next).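

In this assay, putting isoquinolin-8-yl in place of phenyl on the oxygen gives a 2.9-fold higher number from compound 3 to compound 4 (0.46 log units; beyond the scatter) and this step lies beyond the scatter, so the compound is removed faster. The earlier single change, 4-methylpiperazin-1-yl in place of trifluoromethyl, gave a 1.4-fold higher number from compound 2 to compound 3 (0.15 log units; within the scatter) and stayed within the scatter, which makes the group on this oxygen the one place among these compounds where a single swap clearly moves the number. Nothing available explains the rise or shows whether the added ring or its nitrogen is responsible.

A naphthyl group on the same oxygen would keep two rings of carbon only, while a pyridinyl group would keep a ring nitrogen in a single ring, and these two groups could begin to separate the two features. Also open, as far as these compounds go, is whether isoquinolin-8-yl gives a similar step when trifluoromethyl stands in place of 4-methylpiperazin-1-yl, as in compound 2.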